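Swapping the furan of compound 1 for a nitro-toluene ring

The compounds below may be only part of what the source reports. "The series", "measured", "known", "first", "only" and "open" are said of these compounds alone.

Measured compounds:
compound 1 `OC[C@H]1O[C@@H](n2cnc3c(NCc4ccco4)ncnc32)[C@H](O)[C@@H]1O`: 36300 nM
compound 2 `OC[C@H]1O[C@@H](n2cnc3c(CSc4cccc(Br)c4)ncnc32)[C@H](O)[C@@H]1O`: 363 nM

In an assay on isolated protein for binding affinity to Equilibrative nucleoside transporter 1 (Homo sapiens) (a lower number here means a stronger inhibitor, a higher number a weaker inhibitor), compound 1 gives 36300 nM, the highest of the two numbers, so it is the weaker inhibitor of the pair. Compound 2 gives 363 nM, and the step of a 100-fold lower number from compound 1 to compound 2 (2.00 log units; beyond the scatter) came with both the linker and the aryl group changing at once. Compound 3 `Cc1ccc([N+](=O)[O-])c(CNc2ncnc3c2ncn3[C@@H]2O[C@H](CO)[C@@H](O)[C@H]2O)c1` keeps the linker of compound 1 and alters only the aryl end: 5-methyl-2-nitrophenyl in place of furan-2-yl on a saturated chain carbon bound to a nitrogen on an aromatic ring. Within the data shown here, no measured step changes the aryl group alone, so the single comparison available only shows that an aryl change on this side of the core can move the number a great deal. Among the measured compounds shown here, a step to a lower number, smaller than the one to compound 2, is therefore expected, giving an 18-fold lower number from compound 1 to compound 3 (1.26 log units; beyond the scatter). Compound 3 is estimated at 2000 nM, within a range from 300 nM to 15000 nM.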

Compound 3, half-maximal inhibitory concentration: 1290 nM
Estimate against measurement, compound 3: 1.6-fold (0.19 log units) above; measured number inside the range.
By their numbers in this assay, from the lowest: compound 2; then compound 3; then compound 1.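

In this assay the linker of compound 1 stays in place and only the aryl end changes, yet this alone gives a large step (a 28-fold lower number from compound 1 to compound 3 (1.45 log units; beyond the scatter)). The earlier step changed linker and aryl group together, so it could not show that this position responds to the aryl group with the amino link kept. The change swaps a five-membered ring for a larger six-membered carbon ring carrying two substituents, and nothing measured here explains why the number falls.

Going by these compounds, whether a plain phenyl ring would give a similar step, or whether the nitro group or the methyl group accounts for it, stays open. On these data alone, it is also open how 5-methyl-2-nitrophenyl would behave on the sulfanylmethyl link of compound 2, or with an amine in place of the nitro group.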